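A few compounds are considered here, and "the series" means these few. Any claim that something is new, unique, unknown or untested is made for them only; others in the source may bear on it.

Measured in a functional assay on Caco-2 cells (Homo sapiens) for inhibition, read by MTT assay, with a stated time of 48 h; on this read-out higher numbers stand for weaker inhibition of growth and lower numbers for stronger inhibition of growth
- compound 1 (`CN1CC[C@H](c2c(O)cc(O)c3c(=O)cc(/C=C/c4ccccc4)oc23)[C@H](O)C1`) gives 3700 nM
- compound 2 (`CN1CC[C@H](c2c(O)cc(O)c3c(=O)cc(/C=C/c4ccccc4F)oc23)[C@H](O)C1`) gives 7000 nM

Compound 1 has a single measured neighbour, compound 2, and the two lie within the scatter of each other, so this pair gives no ranking. Compound 3 (`CN1CC[C@H](c2c(O)cc(O)c3c(=O)cc(/C=C/c4ccccc4Cl)oc23)[C@H](O)C1`) has no value yet. Its change from compound 1 is chloro in place of hydrogen on an aromatic carbon and reads as chloro in place of hydrogen on an aromatic carbon, ortho to a large group, or phenyl to 2-chlorophenyl.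

Going by the values given here, the one measured step that bears on this is fluoro in place of hydrogen on an aromatic carbon (a 1.9-fold higher number from compound 1 to compound 2 (0.28 log units; within the scatter)). A single step within the scatter is thin evidence, and no chloro comparison exists in the series. In this assay no step beyond the scatter is therefore expected, and no direction can be firmly assigned. The expected step is a 1.4-fold higher number from compound 1 to compound 3 (0.13 log units; within the scatter) as a working estimate. For compound 3 the estimated value is 5000 nM with an expected range from 2000 nM to 12000 nM as its limits.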

Compound 3, concentration for 50% growth inhibition: 9000 nM
Beside the measured number, compound 3's estimate is 1.8-fold (0.26 log units) below it, and the stated range covers the measured number.
By their numbers in this assay, from the lowest: compounds 1, 2 and 3 (each within the scatter of the next, the first and the last beyond it).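

In this assay, going by these compounds alone, the change from phenyl to 2-chlorophenyl gives the first step at this position that clears the scatter (modest in size): a 2.4-fold higher number from compound 1 to compound 3 (0.39 log units; beyond the scatter) on this read-out, which means weaker inhibition of growth with chloro than with hydrogen on this aromatic carbon. Exchanging one halogen for the other at the same place does not separate the two halogen compounds (a 1.3-fold higher number from compound 2 to compound 3 (0.11 log units; within the scatter)), so compound 2 cannot be ranked against compound 3, and only compound 3 stands clear of compound 1. Nothing measured here accounts for the step from hydrogen to chloro.

Within the data shown here, the series so far covers only hydrogen, fluoro and chloro at one place, ortho to a large group, so it remains open whether a chloro group on another aromatic carbon of the same phenyl would give a similar step. Also open, going by these compounds, is how a methoxy group, an amine or a carboxylic acid at this place would compare with the two halogens and with hydrogen.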